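The source may report more compounds than this note shows. Statements on the series, on what has been measured and on what is new or still open speak of the compounds shown alone.

Three compounds share one core and differ only in the groups on its two aryl rings. Compound 1 `COc1cc(Nc2nc3ccccc3nc2S(=O)(=O)c2ccccc2)cc(OC)c1` gives 50 nM in a functional assay on HL-60 cells (Homo sapiens) for cytotoxicity, read by MTT assay, with a stated time of 72 h; on this read-out higher numbers stand for weaker inhibition and lower numbers for stronger inhibition. Compound 2 `COc1cc(Nc2nc3ccccc3nc2S(=O)(=O)c2ccc(C)cc2)cc(OC)c1` gives 20 nM, and compound 3 `COc1cc(Nc2nc3ccccc3nc2S(=O)(=O)c2ccc(C)cc2)cc(OC)c1OC` gives 320 nM. Among these three, compound 2 stands at the lowest number, and its steps to both others lie beyond the scatter.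

Two single changes have been measured. There is a 2.5-fold lower number from compound 1 to compound 2 (0.40 log units; beyond the scatter), and there is a 16-fold higher number from compound 2 to compound 3 (1.20 log units; beyond the scatter), which shows that this assay reacts strongly to a change on the ring that hangs from the nitrogen.

Compound 4 `Cc1ccc(S(=O)(=O)c2nc3ccccc3nc2Nc2ccc(Cl)cc2)cc1` differs from compound 2 in a single place: 4-chlorophenyl in place of 3,5-dimethoxyphenyl on a nitrogen on an aromatic ring. For the measured compounds named here, no measured step covers this exchange, since the step from compound 2 to compound 3 adds a group to that ring while the new change replaces the whole ring. The large size of the step from compound 2 to compound 3 suggests that this ring matters, so a weakening is expected, but its size is uncertain.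

For compound 4 the expected value in this assay is 80 nM, with a range from 20 nM to 400 nM, which would be a 4.0-fold higher number from compound 2 to compound 4 (0.60 log units; beyond the scatter).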

Compound 4, half-maximal inhibitory concentration: 17500 nM
The estimate for compound 4 lay 220-fold (2.34 log units) below the measured number; measured number outside the range, above it.
By their numbers in this assay, from the lowest: compound 2; then compound 1; then compound 3; then compound 4.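

In this assay, exchanging the whole ring on the nitrogen gives an 880-fold higher number from compound 2 to compound 4 (2.94 log units; beyond the scatter), a larger step than a 16-fold higher number from compound 2 to compound 3 (1.20 log units; beyond the scatter), so this position responds even more strongly to replacing the 3,5-dimethoxyphenyl group than to adding a methoxy group to it. The result also shows that 4-chlorophenyl cannot stand in for 3,5-dimethoxyphenyl here, even though both are six-membered aromatic rings of carbon only, joined to the shared core at the same nitrogen. No measurement offered here explains why this exchange has such a large effect.

The exchange removes both methoxy groups and brings in a chlorine atom in one step, so the compounds shown cannot separate the loss of the methoxy groups from the arrival of the chlorine. A plain phenyl ring, a pyridyl ring or a cyclohexyl group on that nitrogen would help show which features of the ring matter, and whether any replacement can come close to the number of compound 2 at 20 nM.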